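Trimming the isopentyl chain to butyl

The source may hold more compounds than are shown below. What is called first, only, known or untested is meant among the compounds shown, and "the series" means these compounds.

Measured in a functional assay on MCF7 cells (Homo sapiens) for inhibition, read by fluorescence, with a stated time of 72 h; a higher number here means a weaker inhibitor of growth, a lower number a stronger inhibitor of growth:
- compound 1 `CCCCn1cnc2c(NCc3cccc(Cl)c3)nc(N[C@H]3CC[C@H](N)CC3)nc21` gives 2200 nM
- compound 2 `CC(C)CCn1cnc2c(Nc3ccccc3)nc(N[C@H]3CC[C@H](N)CC3)nc21` gives 5400 nM

Of these two measured compounds, compound 2 has the higher number (5400 nM), which makes it the weaker inhibitor of growth. Compound 1 has the lower number (2200 nM), and the gap between them lies beyond the scatter.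

Compound 3 `CCCCn1cnc2c(Nc3ccccc3)nc(N[C@H]3CC[C@H](N)CC3)nc21` is still unmeasured. It has hydrogen in place of methyl on a saturated chain carbon bound to two saturated chain carbons, so the isopentyl of compound 2 becomes butyl (hydrogen in place of methyl on a saturated chain carbon bound to two saturated chain carbons). Among the compounds with values here, no measured pair isolates this change, so the series offers no direct precedent for its size.

The estimate is therefore anchored on compound 2 (5400 nM). Only a small change is expected in this assay, within the scatter and with no firm direction (expected: a 1.2-fold lower number from compound 2 to compound 3 (0.08 log units; within the scatter)). For compound 3 the expected value is 4500 nM (estimated range 2200 nM to 9500 nM).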

Compound 3, concentration for 50% growth inhibition: 2200 nM
The estimate for compound 3 lay 2.0-fold (0.31 log units) above the measured number; the range from low to high includes it.
By their numbers in this assay, from the lowest: compounds 1 and 3 (each within the scatter of the next); then compound 2.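

In this assay, removing the methyl on a saturated chain carbon bound to two saturated chain carbons, which turns isopentyl into butyl, gives a 2.5-fold lower number from compound 2 to compound 3 (0.39 log units; beyond the scatter) and is the one step shown here that lies beyond the scatter. With the butyl chain held constant, phenyl in place of 3-chlorobenzyl on a nitrogen on an aromatic ring gives no change at the digits printed from compound 1 to compound 3 (within the scatter) and so does not separate these two groups in this assay. Nothing available bears on the origin of either step.

The compounds shown leave open whether the step from isopentyl to butyl holds with 3-chlorobenzyl in place of phenyl, since the chain change is seen only with phenyl. On these data alone, it also remains open how the number responds to a shorter chain such as propyl, a longer chain such as hexyl, or a chain ending in an amine or a carboxylic acid.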